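Shortening the amide alkyl chain on the tetrahydrobenzothiophene series

This account rests on a few compounds, and the source may have more. Where it says the series, first, only, none or still open, it means among the compounds named here.

Compound 1 `O=C(Nc1sc2c(c1C(=O)NNc1ccc(Br)cc1)CCCCC2)NS(=O)(=O)c1ccccc1` and compound 2 `CCCCNC(=O)c1c(NC(=O)NS(=O)(=O)c2ccccc2)sc2c1CCCCC2` share the sulfonylurea-bearing core and differ only at the amide-type nitrogen. In a functional assay on cells (Leukemia cell, Homo sapiens) for inhibition, with a stated time of 48 h (on this read-out higher numbers stand for weaker inhibition of growth and lower numbers for stronger inhibition of growth), compound 1 gives only a limit, > 100000 nM. In this assay compound 2 likewise gives only a limit, > 100000 nM. Within the data shown here, the step that the two limits leave unreadable from compound 1 to compound 2 therefore cannot be read, and the only evidence on the series is the limit of > 100000 nM in this assay, at which 2 of the 2 values shown sit.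

Compound 3 `CCCNC(=O)c1c(NC(=O)NS(=O)(=O)c2ccccc2)sc2c1CCCCC2` follows from compound 2 by hydrogen in place of methyl on a saturated chain carbon, three bonds along the chain from an amide-type nitrogen. No measured step can be read for guidance, and the change is a small one on the chain. With compound 2 at a limit of > 100000 nM, compound 3 is expected to remain near or at the same limit. The estimate for compound 3 is 150000 nM, with a range from 50000 nM to 500000 nM. The expected step is then a step that the limit leaves unreadable from compound 2 to compound 3, none beyond the scatter.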

Compound 3, concentration for 50% growth inhibition: 42200 nM
Compound 3: middle estimate off by 3.6-fold (0.55 log units), on the high side; measured number outside the range, below it.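

In this assay, the chain on the amide-type nitrogen gives the first readable result of the series: butyl to propyl, hydrogen in place of methyl three bonds along the chain from that nitrogen, gives an at least 2.3-fold lower number from compound 2 to compound 3 (0.37 log units; beyond the scatter). Propyl in place of (4-bromophenyl)amino on the same nitrogen gives an at least 2.3-fold lower number from compound 1 to compound 3 (0.37 log units; beyond the scatter), so this position does respond to change, and the loss of one methyl is enough to bring a value inside the measurable range. Only compound 3 carries a number, and the step between the other two cannot be read: the limit of > 100000 nM in this assay, at which 2 of the 3 values shown sit.

From the compounds shown here alone, both readable steps are bounded on one side only, so their true size stays open. Also open, going by these compounds, is whether ethyl or methyl on the amide-type nitrogen continues this direction, and how a chain carrying an amine or a carboxylic acid would read.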